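Swapping the dichlorophenyl for a trifluoromethylphenyl group

A few compounds are considered here, and "the series" means these few. Any claim that something is new, unique, unknown or untested is made for them only; others in the source may bear on it.

Compound 1 `CCCS(=O)(=O)Nc1ccc(F)c(C(=O)c2n[nH]c3ncc(-c4ccccc4)cc23)c1F` and compound 2 `CCCS(=O)(=O)Nc1ccc(F)c(C(=O)c2n[nH]c3ncc(-c4ccc(Cl)c(Cl)c4)cc23)c1F` share one core and differ only in the aryl group on it. In an assay for binding affinity to dual specificity mitogen-activated protein kinase kinase 4 (Homo sapiens), read by KINOMEscan, tested at 100 nM (a lower number here means a stronger effect, a higher number a weaker effect of the compound at the concentration tested), compound 1 gives 2.4%, and compound 2 gives 45%. Compound 2 therefore stands as the higher of the two numbers, the weaker binder, after the step of a number 42.6 percentage points higher from compound 1 to compound 2 (beyond the scatter).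

Compound 3 `CCCS(=O)(=O)Nc1ccc(F)c(C(=O)c2n[nH]c3ncc(-c4ccc(C(F)(F)F)cc4)cc23)c1F` has not yet been measured. It carries 4-(trifluoromethyl)phenyl in place of 3,4-dichlorophenyl on an aromatic carbon. Among the measured compounds shown here, no measured step changes exactly this pair of groups, so the only guide is the step from compound 1 to compound 2, which shows that adding groups to the phenyl moved the number far upward. Compound 3 keeps a group on the phenyl, so its number is expected to stay well above that of compound 1. The step of a number 15 percentage points lower from compound 2 to compound 3 (beyond the scatter) is the expected outcome. Compound 3 is estimated at 30%, within a range of 5% to 70%.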

Compound 3, a percentage reported as activity, at one concentration (the size of the read-out at that concentration, not a potency): 29%
The estimate for compound 3 lay 1 percentage points above the measured number; the measured number falls inside the stated range.
By their numbers in this assay, from the lowest: compound 1; then compound 3; then compound 2.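

In this assay, the step of a number 26.6 percentage points higher from compound 1 to compound 3 (beyond the scatter) shows that the rise seen with 3,4-dichlorophenyl is not tied to chlorine: a single trifluoromethyl in place of hydrogen also moves the number well up. The step of a number 16 percentage points lower from compound 2 to compound 3 (beyond the scatter) adds that the size of the rise depends on what the phenyl carries, so across these three compounds, both substituted phenyl groups read higher than the plain phenyl, but not equally. The 4-(trifluoromethyl)phenyl also has more heavy atoms than the 3,4-dichlorophenyl yet gives the lower number, so heavy-atom count alone does not follow the read-out in this pair.

Still open, on these data alone, is whether any group on this phenyl keeps the number near that of compound 1, such as a methoxy group or an amine. Nothing available here explains why these numbers differ.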